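The compounds below may be only part of what the source reports. "The series", "measured", "known", "first", "only" and "open" are said of these compounds alone.

In a physicochemical assay for solubility, read by spectrophotometry, in phosphate buffer, with a stated time of 2 h, at pH 7.4 (on this read-out higher numbers stand for higher solubility and lower numbers for lower solubility), compound 1 (`COc1ccc2[nH]c(C(=O)N3CC(=O)N(Cc4ccccc4)[C@@H](COc4ccccc4)C3)cc2c1`) gives 12200 nM and compound 2 (`COc1cccc(CN2C(=O)CN(C(=O)c3cc4cc(OC)ccc4[nH]3)C[C@@H]2COCc2ccccc2)c1`) gives 11700 nM, so the two stand level within the usual scatter. Compound 3 (`COc1ccc2[nH]c(C(=O)N3CC(=O)N(Cc4ccccc4)[C@@H](CN4CCC(C)CC4)C3)cc2c1`) keeps the core of compound 1 but carries 4-methylpiperidin-1-yl in place of phenoxy on a saturated chain carbon bound to a saturated ring carbon. Among the measured compounds shown here, no measured pair shows what such a swap does, so any expectation in this assay is a judgement, and it points to a moderate upward move beyond the scatter. The expected change is a 3.3-fold higher number from compound 1 to compound 3 (0.52 log units; beyond the scatter). For compound 3 the estimated value is 40000 nM, with an expected range of 12000 nM to 130000 nM.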

Compound 3, solubility: 93100 nM
Compound 3: the middle estimate sits 2.3-fold (0.37 log units) below what was measured; the range from low to high includes it.
By their numbers in this assay, from the lowest: compounds 2 and 1 (each within the scatter of the next); then compound 3.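

On a saturated chain carbon bound to a saturated ring carbon, 4-methylpiperidin-1-yl in place of phenoxy gives a 7.6-fold higher number from compound 1 to compound 3 (0.88 log units; beyond the scatter) in this assay, the first step seen at this position. The position therefore responds to the group it carries, even though both groups have the same heavy-atom count and the same hydrogen-bond counts. Nothing available explains this rise. The compounds shown do not separate the effect of the ring nitrogen from the loss of the aromatic ring. A cyclohexyl ring or a morpholin-4-yl ring on this carbon would help tell these apart.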